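Ring nitrogen substituent series: sulfonyl in place of carbonyl

The source may report more compounds than this note shows. Statements on the series, on what has been measured and on what is new or still open speak of the compounds shown alone.

Of the compounds shown here, three sharing one core have been measured in a functional assay on HepG2 cells (Homo sapiens) for cytotoxicity, read by MTT assay, with a stated time of 48 h; a higher number here means a weaker inhibitor, a lower number a stronger inhibitor. Compound 1 `Cc1ccc(C(=O)N2N=C(c3cc4ccccc4oc3=O)CC2c2ccccc2)cc1` gives 52300 nM. Compound 2 `CCC(=O)N1N=C(c2cc3ccccc3oc2=O)CC1c1ccccc1` gives 9610 nM. Compound 3 `O=C(c1ccccc1Cl)N1N=C(c2cc3ccccc3oc2=O)CC1c1ccccc1` gives 5440 nM, the lowest of the three numbers, though its gap to compound 2 is within the scatter. The steps of a 5.4-fold lower number from compound 1 to compound 2 (0.74 log units; beyond the scatter) and a 9.6-fold lower number from compound 1 to compound 3 (0.98 log units; beyond the scatter) are both beyond the scatter, while a 1.8-fold lower number from compound 2 to compound 3 (0.25 log units; within the scatter) is within it.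

Compound 4 `Cc1ccc(S(=O)(=O)N2N=C(c3cc4ccccc4oc3=O)CC2c2ccccc2)cc1` is not yet measured. The change is (4-methylphenyl)sulfonyl in place of (2-chlorophenyl)carbonyl on an amine nitrogen in a ring. Among the compounds with values here, no measured step exchanges a carbonyl for a sulfonyl, so the three steps bear on it only loosely: changing the group on the carbonyl carbon moved the number at most as far as a 9.6-fold lower number from compound 1 to compound 3 (0.98 log units; beyond the scatter) shows, and the 4-methylphenyl variant, compound 1, gave the highest number. A modest rise in the number from compound 3 is therefore expected. For compound 4 the expected step in this assay is a 2.8-fold higher number from compound 3 to compound 4 (0.44 log units; beyond the scatter). Compound 4 is estimated at 15000 nM, in the range 4000 nM to 60000 nM.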

Compound 4, half-maximal inhibitory concentration: "not active" (no number reported)
No number was reported for compound 4, and the estimate cannot be compared.
By their numbers in this assay, from the lowest: compounds 3 and 2 (each within the scatter of the next); then compound 1.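

In this assay, within the data shown here, compound 4 is reported as "not active" without a number, so no step from compound 1, compound 2 or compound 3 to compound 4 can be read. Nothing shown here accounts for this result. The compounds shown leave open how far, in numbers, the (4-methylphenyl)sulfonyl group of compound 4 stands from the carbonyl-linked groups.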